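Replacing 1-carboxyethyl on the amide nitrogen

The source may report more compounds than this note shows. Statements on the series, on what has been measured and on what is new or still open speak of the compounds shown alone.

In a functional assay on PC-3 cells (Homo sapiens) for antiproliferative activity, read by MTT assay, with a stated time of 48 h (a higher number here means a weaker inhibitor, a lower number a stronger inhibitor), compound 1 `C#CCCOC(=O)c1ccc(C(CC)(CC)c2ccc(OCCC(O)(CC)CC)c(C)c2)n1CC` gives > 50000 nM, which is a limit and not a number. Compound 2 `CCC(C)C(NC(=O)c1ccc(C(CC)(CC)c2ccc(OCCC(O)(CC)CC)c(C)c2)n1CC)C(=O)O` gives 13800 nM. Compound 3 `CCn1c(C(=O)NC(C)C(=O)O)ccc1C(CC)(CC)c1ccc(OCCC(O)(CC)CC)c(C)c1` gives 11700 nM, matching compound 2 within the scatter. Compound 4 `CCC(C)C(CO)NC(=O)c1ccc(C(CC)(CC)c2ccc(OCCC(O)(CC)CC)c(C)c2)n1CC` differs from compound 3 as follows: 1-(hydroxymethyl)-2-methylbutyl in place of 1-carboxyethyl on an amide-type nitrogen. Replacing (but-3-yn-1-yl)oxy with a carboxy-bearing amino group gave an at least 3.6-fold lower number from compound 1 to compound 2 (0.55 log units; beyond the scatter) and an at least 4.2-fold lower number from compound 1 to compound 3 (0.63 log units; beyond the scatter). Swapping sec-butyl for methyl gave only a 1.2-fold lower number from compound 2 to compound 3 (0.07 log units; within the scatter). Within the data shown here, no measured step changes the carboxy part alone. The expected step is small and within the scatter, towards a higher number: a 1.4-fold higher number from compound 3 to compound 4 (0.14 log units; within the scatter). For compound 4 the estimated value is 16000 nM, with an expected range of 5000 nM to 50000 nM.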

Compound 4, half-maximal inhibitory concentration: 28400 nM
The estimate for compound 4 lay 1.8-fold (0.25 log units) below the measured number; the measured number falls inside the stated range.
By their numbers in this assay, from the lowest: compounds 3 and 2 (each within the scatter of the next); then compound 4. At a limit, above all of these: compound 1.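

In this assay, the change of the carboxy part alone can now be read: hydroxymethyl in place of carboxy, with the sec-butyl chain kept, weakens the compound (a 2.1-fold higher number from compound 2 to compound 4 (0.31 log units; beyond the scatter)). The wider swap on the amide nitrogen gives a step of similar size (a 2.4-fold higher number from compound 3 to compound 4 (0.39 log units; beyond the scatter)), so compound 4 sits beyond the scatter from both carboxy compounds. Against compound 1 only a floor can be read (an at least 1.7-fold lower number from compound 1 to compound 4 (0.24 log units; that floor lies within the scatter)), and compound 1 stands at a limit: the limit of > 50000 nM in this assay, at which 1 of the 4 values shown sits.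

On these data alone, whether an amine or a methyl ester in place of the carboxy would track compound 2 or compound 4 stays open. So does the effect of hydroxymethyl on the shorter chain of compound 3.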